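From 4-aminophenyl to 3,4-difluorophenyl in a growth inhibitor

This account rests on a few compounds, and the source may have more. Where it says the series, first, only, none or still open, it means among the compounds named here.

compound 1 `COc1cc(-c2cc(/C=C/C(=O)c3ccc(N)cc3)[nH]n2)cc(OC)c1OC` with 3670 nM
compound 2 `COc1cc(-c2cc(/C=C/C(=O)c3ccc(Cl)c(Cl)c3)[nH]n2)cc(OC)c1OC` with > 100000 nM (a limit)

In a functional assay on ACHN cells (Homo sapiens) for inhibition, read by sulforhodamine B assay, with a stated time of 48 h (a higher number here means a weaker inhibitor of growth, a lower number a stronger inhibitor of growth), compound 1 gives 3670 nM as the only true number shown. Compound 2 gives > 100000 nM and that is a limit of the assay, not a number.

Compound 3 `COc1cc(-c2cc(/C=C/C(=O)c3ccc(F)c(F)c3)[nH]n2)cc(OC)c1OC` has yet to be measured. It keeps the core of compound 1 and differs from it in one place (3,4-difluorophenyl in place of 4-aminophenyl on a carbonyl carbon) on a carbonyl carbon.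

Among the measured compounds shown here, compound 2 holds the one measured step that bears on this, 3,4-dichlorophenyl in place of the same 4-aminophenyl, and with its an at least 27-fold higher number from compound 1 to compound 2 (1.43 log units; beyond the scatter) in view a large step to a higher number is expected for compound 3 in this assay as well. A single step is thin ground, so the expected size stays wide. The expected step is an 8.2-fold higher number from compound 1 to compound 3 (0.91 log units; beyond the scatter) and the result could also come back only as a limit. For compound 3 the estimate is 30000 nM with an expected range of 7000 nM to 100000 nM as its bounds.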

Compound 3, concentration for total growth inhibition: > 100000 nM
Compound 3 ended at the assay's limit; the forecaster's own chance of this, stated with the estimate: 40%; middle value at least 3.3-fold (0.52 log units) away from the limit.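

In this assay, putting 3,4-difluorophenyl in place of 4-aminophenyl on the carbonyl carbon gives an at least 27-fold higher number from compound 1 to compound 3 (1.43 log units; beyond the scatter), so the loss seen with the 3,4-dichlorophenyl of compound 2 is not confined to that one group, and of the three compounds only compound 1, with its 4-aminophenyl, gives a true number. Compound 3 gives > 100000 nM, which is a limit of the assay and not a number. Compound 2 and compound 3 both stand at limits, so the step between them cannot be read and neither can be ranked against the other, which means that nothing can be said on whether fluorine or chlorine does better here: the limit of > 100000 nM in this assay, at which 2 of the 3 values shown sit.

The compounds shown leave open whether the amine of compound 1 is itself what keeps a measurable growth inhibition or whether other groups on the same phenyl would serve as well. A hydroxyl, a methoxy group or a dimethylamino group in place of the amine would help to separate these two readings.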